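Cytotoxicity notes: indolyl to cyano on the shared core

The source may report more compounds than this note shows. Statements on the series, on what has been measured and on what is new or still open speak of the compounds shown alone.

Compound 1 `Cc1cc(N2CCN(C)CC2)c2ncc(CSCCc3ccccc3)n2c1` has, in an ADME assay on HEL cells (Homo sapiens) for cytotoxicity, with a stated time of 3 days (a lower number here means that less compound is tolerated, a higher number that more compound is tolerated), only the entry "not determined" (no result reported) and no number. Going by the values given here, compound 2 `Cc1cc(-n2ccc3ccccc32)c2ncc(CSCCc3ccccc3)n2c1` gives the only number here: in this assay compound 2 shows 100 ug/mL. Compound 3 `Cc1cc(C#N)c2ncc(CSCCc3ccccc3)n2c1` carries the change cyano in place of 1H-indol-1-yl on an aromatic carbon at the position described for it. Among the compounds with values here, no measured step is available for this pair, so the expectation rests on compound 2 alone; the change from compound 2 to compound 3 is expected to stay within the scatter of this assay, with no clear direction, as no change at the digits printed from compound 2 to compound 3 (within the scatter). Compound 3 is therefore estimated at 100 ug/mL, with a range of 35 ug/mL to 300 ug/mL.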

Compound 3, minimum cytotoxic concentration: >= 20 ug/mL
Compound 3: no number, only a limit (the forecaster's own chance of this, stated with the estimate: 40%); the middle value does not contradict the limit.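

Going by these compounds alone, compound 3 gives only a limit, so no step from compound 2 to compound 3 can be read: the limit of >= 20 ug/mL in this assay, at which 1 of the 3 values shown sits. Going by these compounds, whether cyano in place of 1H-indol-1-yl shifts the tolerated concentration in this assay stays open.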